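A few compounds are considered here, and "the series" means these few. Any claim that something is new, unique, unknown or untested is made for them only; others in the source may bear on it.

In an ADME assay on BE(2)-C cells (Homo sapiens) for cytotoxicity, read by MTT assay, with a stated time of 20 h (a higher number here means that more compound is tolerated, a lower number that less compound is tolerated), compound 3 `O=C(NCCn1ccnc1)C1CCN(C(=O)c2cc3ccccc3n2Cc2ccc(Cl)cc2)CC1` gives 99600 nM and compound 2 `O=C(NCCCc1ccncc1)C1CCN(C(=O)c2cc3ccccc3n2Cc2ccc(Cl)cc2)CC1` gives 71500 nM, two values within the scatter of each other. Compound 1 `CN1CCC(CNC(=O)C2CCN(C(=O)c3cc4ccccc4n3Cc3ccc(Cl)cc3)CC2)CC1` reads > 50000 nM, which is a limit and not a number, so its steps to the other two have no readable size. Compound 4 `O=C(c1cc2ccccc2n1Cc1ccc(Cl)cc1)N1CCC(C(=O)N2CCCC2)CC1` carries pyrrolidin-1-yl in place of (2-(1H-imidazol-1-yl)ethyl)amino on a carbonyl carbon. Among the measured compounds shown here, no measured step makes this exchange. For the measured compounds named here, no step beyond the scatter is expected in this assay, because a 1.4-fold higher number from compound 2 to compound 3 (0.14 log units; within the scatter) is the only readable change in this side chain. The estimated step is a 1.2-fold lower number from compound 3 to compound 4 (0.07 log units; within the scatter). For compound 4 the expected value is 85000 nM, with an estimated range of 40000 nM to 170000 nM.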

Compound 4, half-maximal cytotoxic concentration: 65600 nM
Estimate against measurement, compound 4: 1.3-fold (0.11 log units) above; measured number inside the range.
By their numbers in this assay, from the lowest: compounds 4, 2 and 3 (each within the scatter of the next).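

In this assay, exchanging the amine part on the carbonyl carbon for pyrrolidin-1-yl gives a 1.5-fold lower number from compound 3 to compound 4 (0.18 log units; within the scatter) and a 1.1-fold lower number from compound 2 to compound 4 (0.04 log units; within the scatter). This position therefore accepts a side chain without the five-membered aromatic ring and the hydrogen-bond donor of compound 3, with no step beyond the scatter. Compound 1 carries a limit, so its steps to the other compounds cannot be read: the limit of > 50000 nM in this assay, at which 1 of the 4 values shown sits.

Open: whether a carboxylic acid or a long alkyl chain on this carbonyl carbon would also stay within the scatter.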